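From pyrrolidin-1-yl to benzylamino on a carbonyl carbon

A few compounds are considered here, and "the series" means these few. Any claim that something is new, unique, unknown or untested is made for them only; others in the source may bear on it.

Measured so far in a functional assay on U-937 cells (Homo sapiens) for antiproliferative activity, read by MTT assay, with a stated time of 24 h; a higher number here means a weaker inhibitor, a lower number a stronger inhibitor:
- compound 1 (`CCCCNC(=O)COc1ccc(C(=O)c2c(CCCC)oc3ccccc23)cc1`) gives 22800 nM
- compound 2 (`CCCCc1oc2ccccc2c1C(=O)c1ccc(OCC(=O)N2CCCC2)cc1`) gives 32500 nM
- compound 3 (`CCCCc1oc2ccccc2c1C(=O)c1ccc(OCC(=O)N2CCN(C(=O)OC(C)(C)C)CC2)cc1`) gives 23700 nM

Compound 2 (32500 nM) stands within the scatter of both compound 1 and compound 3, so the three values form a single level with no ranking among them. The next compound to be tested is compound 4 (`CCCCc1oc2ccccc2c1C(=O)c1ccc(OCC(=O)NCc2ccccc2)cc1`), which has benzylamino in place of pyrrolidin-1-yl on a carbonyl carbon. Counted out, the difference is benzylamino in place of pyrrolidin-1-yl on a carbonyl carbon and the rest of the structure stays the same.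

Within the data shown here, only one measured step bears directly on this change. It is a 1.4-fold higher number from compound 1 to compound 2 (0.15 log units; within the scatter), for pyrrolidin-1-yl in place of butylamino at that same carbonyl carbon. Compound 3 (23700 nM) also shows a value at this level. Among the measured compounds shown here, no measured compound yet carries benzylamino, so this evidence is indirect. The step expected here is a 1.3-fold lower number from compound 2 to compound 4 (0.11 log units; within the scatter), which means none beyond the scatter. In this assay compound 4 is expected at 25000 nM (estimated range 12000 nM to 45000 nM).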

Compound 4, half-maximal inhibitory concentration: 16300 nM
Estimate against measurement, compound 4: 1.5-fold (0.19 log units) above; the range from low to high includes it.
By their numbers in this assay, from the lowest: compounds 4, 1, 3 and 2 (each within the scatter of the next).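

In this assay, among these compounds, a 2.0-fold lower number from compound 2 to compound 4 (0.30 log units; within the scatter) when benzylamino replaces pyrrolidin-1-yl on the carbonyl carbon, so this position accepts a six-membered aromatic ring of carbon only, together with the amide hydrogen, without leaving the level set by the earlier compounds. Phenyl in place of propyl on the saturated chain carbon bound to an amide-type nitrogen gives a 1.4-fold lower number from compound 1 to compound 4 (0.15 log units; within the scatter), so in this series an aromatic end on the amide nitrogen reads the same as a saturated one within the scatter of this assay. Nothing measured here offers a reason why such different groups leave the number at one level.

The four compounds therefore leave open whether any group on this carbonyl carbon can move the number beyond the scatter, for instance a benzylamino ring bearing an amine or a carboxylic acid, a longer chain between the amide nitrogen and the phenyl ring, or a piperazine without the tert-butoxycarbonyl group that compound 3 carries. They also leave open how far the level depends on the rest of the structure, which all four compounds share unchanged.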